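Two Weakening Changes Combined on One Kinase Inhibitor Scaffold

The compounds below may be only part of what the source reports. "The series", "measured", "known", "first", "only" and "open" are said of these compounds alone.

Three compounds have been measured in an assay on isolated protein for inhibition of RAC-alpha serine/threonine-protein kinase (Homo sapiens), read by 33P incorporation, in the presence of a further agent that is not named here; a higher number here means a weaker inhibitor, a lower number a stronger inhibitor:

compound 1, `CCN1CCN(c2ccc(-c3nn(Cc4cn(Cc5ccccc5)nn4)c4nc(NC)ncc34)cn2)CC1`: 1900 nM
compound 2, `CNc1ncc2c(-c3ccc(N4CCN(C(=O)C(C)(C)C)CC4)nc3)nn(Cc3cn(Cc4ccccc4)nn3)c2n1`: > 10000 nM, which is a limit of the assay and not a number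
compound 3, `CCN1CCN(c2ccc(-c3nn(CC4CCCC4)c4nc(NC)ncc34)cn2)CC1`: > 10000 nM, which is likewise a limit and not a number

Compound 1 is the only one of the three with a numerical value in this assay. From compound 1 to compound 2 the change is (tert-butyl)carbonyl in place of ethyl on an amine nitrogen in a ring and the step is an at least 5.2-fold higher number from compound 1 to compound 2 (0.72 log units; beyond the scatter). From compound 1 to compound 3 the change is cyclopentyl in place of 1-benzyl-1H-1,2,3-triazol-4-yl on a saturated chain carbon bound to an aromatic nitrogen and the step is an at least 5.2-fold higher number from compound 1 to compound 3 (0.72 log units; beyond the scatter). Both steps are bounded only by the limit of > 10000 nM in this assay, at which 2 of the 3 values shown sit, so their true sizes are not known.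

Compound 4, `CNc1ncc2c(-c3ccc(N4CCN(C(=O)C(C)(C)C)CC4)nc3)nn(CC3CCCC3)c2n1`, has not been measured. It differs from compound 3 by (tert-butyl)carbonyl in place of ethyl on an amine nitrogen in a ring, the same change as that from compound 1 to compound 2; the place is described in identical words for both pairs. The cores of compound 3 and compound 4 differ from those of compound 1 and compound 2 by cyclopentyl in place of 1-benzyl-1H-1,2,3-triazol-4-yl on a saturated chain carbon bound to an aromatic nitrogen.

The step that the limit leaves unreadable from compound 3 to compound 4 is an expectation only, and its size cannot be read off, as compound 3 already sits at the limit in this assay. Given that compound 3 is a limit and that the same change on compound 1 gave an at least 5.2-fold higher number from compound 1 to compound 2 (0.72 log units; beyond the scatter), compound 4 is expected to return a limit as well, with an estimated value of 40000 nM, between 10000 nM and 200000 nM.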

Compound 4, half-maximal inhibitory concentration: > 10000 nM
Compound 4 was reported as a limit (the forecaster's own chance of this, stated with the estimate: 92%); the middle value is on the limit's open side.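

Neither the step from compound 3 to compound 4 nor the step from compound 2 to compound 4 can be read, because each of these compounds is reported only as a limit: the limit of > 10000 nM in this assay, at which 3 of the 4 values shown sit.

What the compounds shown leave open is whether compound 2, compound 3 and compound 4 truly differ in this assay, and so what (tert-butyl)carbonyl in place of ethyl does when cyclopentyl is present.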